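The source may hold more compounds than are shown below. What is called first, only, known or untested is meant among the compounds shown, and "the series" means these compounds.

Measured so far:
compound 1 `c1ccc(C2CCCCN2C2CCN(CCCc3c[nH]c4ccc(-n5cnnc5)cc34)CC2)cc1` gives 4.7 nM in an assay on CHO cells for agonist activity at 5-hydroxytryptamine receptor 1D (Homo sapiens), read by GTPgammaS binding; on this read-out higher numbers stand for an effect only at larger amounts of compound and lower numbers for an effect already at smaller amounts
compound 2 `COC[C@H](NC1CCN(CCCc2c[nH]c3ccc(-n4cnnc4)cc23)CC1)c1ccccc1` gives 0.9 nM in this assay

Compound 2 holds the lower of the two numbers; compound 1 stands at a clearly higher value, a gap beyond the usual scatter. Compound 3 `C[C@H](NC1CCN(CCCc2c[nH]c3ccc(-n4cnnc4)cc23)CC1)c1ccccc1` is not yet measured. It differs from compound 2 by hydrogen in place of methoxy on a saturated chain carbon, two bonds along the chain from an amine nitrogen and an aromatic carbon. For the measured compounds named here, no measured pair shows this change, so the expectation rests on compound 2 alone. The expected step is a 2.2-fold higher number from compound 2 to compound 3 (0.35 log units; beyond the scatter), a modest rise in this assay that may still fall near the scatter. Compound 3 is therefore estimated at 2 nM, within a range from 0.7 nM to 6 nM.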

Compound 3, half-maximal effective concentration: 12 nM
Beside the measured number, compound 3's estimate is 6.0-fold (0.78 log units) below it, and the stated range ends below it.
By their numbers in this assay, from the lowest: compound 2; then compound 1; then compound 3.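

In this assay, going from methoxymethyl to methyl on this saturated chain carbon gives a 13-fold higher number from compound 2 to compound 3 (1.12 log units; beyond the scatter), a large step. This position therefore responds strongly to the loss of the methoxy group, although the finding rests on a single pair. No measured evidence accounts for the size of this step.

Hydroxymethyl or ethoxymethyl at this carbon would show whether the ether oxygen or the longer chain tracks with the lower number. From the compounds shown here alone, the effect of methoxy in a different series of substituents on this carbon also remains open.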